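Removing the bromo from compound 2: an expectation

The source may report more compounds than this note shows. Statements on the series, on what has been measured and on what is new or still open speak of the compounds shown alone.

Compound 2 `O=C(CNc1ccc(Br)cc1)Nn1c(-c2ccccc2)nc2ccccc2c1=O` stands highest of the two numbers in a functional assay on A549 cells (Homo sapiens) for cytotoxicity, read by MTT assay, with a stated time of 4 h (a lower number here means a stronger inhibitor, a higher number a weaker inhibitor), where compound 2 gives 25000 nM. Compound 1 `CCc1ccc(NCC(=O)Nn2c(-c3ccccc3)nc3ccccc3c2=O)cc1` in this assay gives 2100 nM, and the step of a 12-fold higher number from compound 1 to compound 2 (1.08 log units; beyond the scatter) is the only measured one at this position. Compound 3 `O=C(CNc1ccccc1)Nn1c(-c2ccccc2)nc2ccccc2c1=O` differs from compound 2 by hydrogen in place of bromo on an aromatic carbon. That single step shows the position matters but does not fix the direction for hydrogen, so the change a 2.5-fold lower number from compound 2 to compound 3 (0.40 log units; beyond the scatter) is expected to be modest. Compound 3 is therefore estimated at 10000 nM, within 3000 nM to 35000 nM.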

Compound 3, half-maximal inhibitory concentration: 13300 nM
Compound 3: the middle estimate sits 1.3-fold (0.12 log units) below what was measured; low and high end bracket the measured number.
By their numbers in this assay, from the lowest: compound 1; then compounds 3 and 2 (each within the scatter of the next).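

In this assay, hydrogen in place of bromo gives a 1.9-fold lower number from compound 2 to compound 3 (0.27 log units; within the scatter) and so separates the two groups by no more than the usual scatter. Hydrogen in place of ethyl gives a 6.3-fold higher number from compound 1 to compound 3 (0.80 log units; beyond the scatter) and stays beyond the scatter, so among these three groups ethyl alone stands apart, with the lowest number. No measurement offered here explains these steps.

From the compounds shown here alone, whether the lower number belongs to ethyl alone or extends to a longer chain such as propyl remains open. So does the effect of an amine or a carboxylic acid on this aromatic carbon.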